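Amide-urea swap with added chloro on the aryl ring

A few compounds are considered here, and "the series" means these few. Any claim that something is new, unique, unknown or untested is made for them only; others in the source may bear on it.

Compound 1 `COc1cc(-c2nn(-c3cccc(NC(=O)c4cccc(C(F)(F)F)c4)c3)cc2-c2ccncc2)ccc1Cl`: 560 nM
Compound 2 `COc1cc(-c2nn(-c3cccc(NC(=O)Nc4ccc(Cl)c(Cl)c4)c3)cc2-c2ccncc2)ccc1Cl`: 150 nM
Compound 3 `COc1cc(-c2nn(-c3cccc(NC(=O)Nc4cccc(C(F)(F)F)c4)c3)cc2-c2ccncc2)ccc1Cl`: 560 nM

In a functional assay on HOP-92 cells (Homo sapiens) for inhibition, read by sulforhodamine B assay, with a stated time of 48 h (on this read-out higher numbers stand for weaker inhibition and lower numbers for stronger inhibition), compound 3 stands level with compound 1, the two together giving the highest numbers of the three, while compound 2 sits a 3.7-fold higher number from compound 2 to compound 3 (0.57 log units; beyond the scatter) apart. Compound 4 `COc1cc(-c2nn(-c3cccc(NC(=O)c4ccc(Cl)c(C(F)(F)F)c4)c3)cc2-c2ccncc2)ccc1Cl` differs from compound 3 by 4-chloro-3-(trifluoromethyl)phenyl in place of (3-(trifluoromethyl)phenyl)amino on a carbonyl carbon. Within the data shown here, two measured steps bear on this. The step of no change at the digits printed from compound 1 to compound 3 (within the scatter) shows that replacing the aryl amide by the corresponding aryl urea changed nothing, so the linker swap itself is not expected to matter. The step of a 3.7-fold lower number from compound 1 to compound 2 (0.57 log units; beyond the scatter) shows that a dichlorophenyl ring in place of a trifluoromethylphenyl ring gave a modest gain, and compound 4 carries both a chloro and a trifluoromethyl group. Compound 4 is therefore expected to give 300 nM (range 120 nM to 900 nM), a step of a 1.9-fold lower number from compound 3 to compound 4 (0.27 log units; within the scatter) in the direction of stronger inhibition.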

Compound 4, half-maximal inhibitory concentration: 670 nM
For compound 4 the middle estimate is 2.2-fold (0.35 log units) below the measured one; the range from low to high includes it.
By their numbers in this assay, from the lowest: compound 2; then compounds 1, 3 and 4 (each within the scatter of the next).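

In this assay, chloro in place of hydrogen on an aromatic carbon of the amide's aryl ring leaves the reading unmoved, a 1.2-fold higher number from compound 1 to compound 4 (0.08 log units; within the scatter), so a chloro on this ring does not by itself bring a gain. The amide with 4-chloro-3-(trifluoromethyl)phenyl also reads level with the urea lacking chloro, a 1.2-fold higher number from compound 3 to compound 4 (0.08 log units; within the scatter), yet stays apart from the 3,4-dichlorophenyl urea, a 4.5-fold higher number from compound 2 to compound 4 (0.65 log units; beyond the scatter). No measurement at hand accounts for this. Still open, from the compounds shown here alone, is how the 3,4-dichlorophenyl ring behaves on the amide, and what a nitrile or a morpholine in place of the chloro would give.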